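From pyrimidin-5-yl to 4-methylpiperazin-1-yl at the assay limit

The source may hold more compounds than are shown below. What is called first, only, known or untested is meant among the compounds shown, and "the series" means these compounds.

- In an ADME assay on THP-1 cells (Homo sapiens) for cytotoxicity, read by MTT assay, with a stated time of 72 h (a lower number here means that less compound is needed, a higher number that more compound is needed for the effect), compound 1 `Cc1ccc(-c2ccc3[nH]c(=O)nc(-c4ccccc4)c3c2)cn1` gives > 50000 nM as a limit.
- In this assay compound 2 `Cc1ccncc1-c1ccc2[nH]c(=O)nc(-c3ccccc3)c2c1` gives > 50000 nM as a limit.
- In this assay compound 3 `O=c1nc(-c2ccccc2)c2cc(-c3cncnc3)ccc2[nH]1` gives > 50000 nM as a limit.

Compound 3 thus has no number to its name, only a limit. Among the compounds with values here, the other two compounds are no different, and the whole set shares the limit of > 50000 nM in this assay, at which 3 of the 3 values shown sit, as its only reading.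

Compound 4 `CN1CCN(c2ccc3[nH]c(=O)nc(-c4ccccc4)c3c2)CC1` carries 4-methylpiperazin-1-yl in place of pyrimidin-5-yl on an aromatic carbon of the shared core, and 4-methylpiperazin-1-yl in place of pyrimidin-5-yl on an aromatic carbon gives the count of that change. Within the data shown here, three measured steps bear on it, all exchanges of the group on that carbon. They are a step that the two limits leave unreadable from compound 1 to compound 2 together with a step that the two limits leave unreadable from compound 1 to compound 3 and a step that the two limits leave unreadable from compound 2 to compound 3 as the closest guides. None of them has a readable size, and none brings in a non-aromatic ring.

Among the measured compounds shown here, no step of definite size or direction can therefore be carried over to this assay. Compound 4 is expected to stay close to the limit that compound 3 shows. The expected change is a number no higher from compound 3 to compound 4 (the limit leaves the size open) as a rough estimate. For compound 4 the estimate is 50000 nM with an expected range from 15000 nM to 100000 nM as its span.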

Compound 4, half-maximal effective concentration: > 50000 nM
Compound 4: no number, only a limit (the forecaster's own chance of this, stated with the estimate: 75%); the middle value sits exactly at the limit.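

Within the data shown here, compound 4 gives only a limit in this assay, as do compound 1, compound 2 and compound 3, so no step from any of them to compound 4 can be read. All four compounds share a single reading: the limit of > 50000 nM in this assay, at which 4 of the 4 values shown sit. The compounds shown leave open whether the group on that aromatic carbon changes cytotoxicity at all.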